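Swapping the aryl group on the triazole nitrogen

This account rests on a few compounds, and the source may have more. Where it says the series, first, only, none or still open, it means among the compounds named here.

Of the compounds shown here, three have been tested in a functional assay on MCF7 cells (Homo sapiens) for cytotoxicity, read by MTT assay, with a stated time of 48 h; on this read-out higher numbers stand for weaker inhibition and lower numbers for stronger inhibition. Compound 1, with the structure `CC(C)=CCC/C(C)=C/CC/C(C)=C/CC[C@@H]1[C@@]2(C)CC/C(=N\OCc3cn(-c4ccc(Cl)cc4)nn3)C(C)(C)[C@@H]2CC[C@@]1(C)O`, gives 12400 nM. Compound 2, with the structure `CC(C)=CCC/C(C)=C/CC/C(C)=C/CC[C@@H]1[C@@]2(C)CC/C(=N\OCc3cn(-c4ccc(F)c(F)c4F)nn3)C(C)(C)[C@@H]2CC[C@@]1(C)O`, gives 32300 nM. Compound 3, with the structure `COc1cccc(-n2cc(COc3ccc(/C=C4\C[C@]5(C)[C@@H](CC/C=C(\C)CC/C=C(\C)CCC=C(C)C)[C@](C)(O)CC[C@H]5C(C)(C)C4=O)cc3)nn2)c1`, gives 16600 nM. Among these three numbers, compound 3 stands second highest; its value and that of compound 1 lie within the usual scatter of each other, and so do its value and that of compound 2, so none of the three can be ranked against another with confidence.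

Compound 4, with the structure `CC(C)=CCC/C(C)=C/CC/C(C)=C/CC[C@@H]1[C@@]2(C)C/C(=C\c3ccc(OCc4cn(-c5ccncc5)nn4)cc3)C(=O)C(C)(C)[C@@H]2CC[C@@]1(C)O`, has not yet been measured. It differs from compound 3 only in the group carried on the aromatic nitrogen of the triazole ring: pyridin-4-yl in place of 3-methoxyphenyl on an aromatic nitrogen.

Going by the values given here, the one measured step that also swaps the group on this aromatic nitrogen is a 2.6-fold higher number from compound 1 to compound 2 (0.42 log units; beyond the scatter). It shows that such a swap, on a related core, can move the number modestly, toward weaker inhibition. A change of this kind in compound 4 is therefore expected to be small, and the estimated step of a 1.1-fold higher number from compound 3 to compound 4 (0.04 log units; within the scatter) lies within or close to the scatter. Compound 4 is thus expected to give about 18000 nM, with a likely range from 7000 nM to 45000 nM.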

Compound 4, half-maximal inhibitory concentration: 37500 nM
The estimate for compound 4 lay 2.1-fold (0.32 log units) below the measured number; the measured number falls inside the stated range.
By their numbers in this assay, from the lowest: compounds 1, 3, 2 and 4 (each within the scatter of the next, the first and the last beyond it).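

In this assay, the swap to pyridin-4-yl from 3-methoxyphenyl gives a 2.3-fold higher number from compound 3 to compound 4 (0.35 log units; beyond the scatter), so the group on this aromatic nitrogen of the triazole also matters on the core of compound 3, not only on the core of compound 1. Alongside a 2.6-fold higher number from compound 1 to compound 2 (0.42 log units; beyond the scatter), this gives two swaps at this position, on two different cores, that both move toward weaker inhibition; only two pairs with different groups are involved, so this is no general rule. The change to compound 4 replaces a carbon-only ring bearing a methoxy group with a ring containing one hetero atom, but no measurement here explains why the number rises.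

From the compounds shown here alone, a plain phenyl group on the core of compound 3 remains open, and it could help separate the loss of the methoxy group from the gain of the ring nitrogen. Also open, going by these compounds, is whether a benzyl group, or a short chain ending in an amine, would give a number closer to that of compound 3 or compound 4 in this cell assay.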